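This account rests on a few compounds, and the source may have more. Where it says the series, first, only, none or still open, it means among the compounds named here.

Compounds measured in a functional assay on SK-MEL-5 cells (Homo sapiens) for inhibition, read by sulforhodamine B assay, with a stated time of 48 h, tested at 10 uM; a lower number here means less inhibition, a higher number more inhibition at the concentration tested (going by the name of the read-out):
compound 1, `c1ccc(-c2cn3ccnc3c(-c3ccc4ncn(C5CCCCC5)c4c3)n2)cc1`, gives 36.5%;
compound 2, `CC(=O)c1ccc(-c2cn3ccnc3c(-c3ccc4ncn(C5CCCCC5)c4c3)n2)cc1`, gives 24.8%;
compound 3, `Brc1ccc(-c2cn3ccnc3c(-c3ccc4ncn(C5CCCCC5)c4c3)n2)cc1`, gives 23.6%.

Compound 3 holds the lowest of the three numbers; its nearest neighbour is compound 2, separated only by a number 1.2 percentage points lower from compound 2 to compound 3 (within the scatter), which lies within the scatter, while compound 1 stands furthest away, as a number 12.9 percentage points lower from compound 1 to compound 3 (beyond the scatter) shows a step beyond the scatter.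

Compound 4, `Fc1ccccc1-c1cn2ccnc2c(-c2ccc3ncn(C4CCCCC4)c3c2)n1`, has not yet been measured. It differs from compound 3 as follows: 2-fluorophenyl in place of 4-bromophenyl on an aromatic carbon. Among the compounds with values here, no measured step involves a fluoro group or a 2-substituted phenyl, so the bearing of the known steps is indirect. The steps of a number 11.7 percentage points lower from compound 1 to compound 2 (beyond the scatter) and a number 12.9 percentage points lower from compound 1 to compound 3 (beyond the scatter) show that placing a group on the phenyl ring lowered the read-out modestly from the unsubstituted compound 1, whereas a number 1.2 percentage points lower from compound 2 to compound 3 (within the scatter) shows that exchanging one group for another changed nothing beyond the scatter. By analogy with that exchange, compound 4 is expected to stay near compound 3, with an estimated step of a number 4.4 percentage points higher from compound 3 to compound 4 (within the scatter). The estimate for compound 4 in this assay is therefore 28%, in a range from 14% to 42%.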

Compound 4, a percentage reported as inhibition, at one concentration (the size of the read-out at that concentration, not a potency): 6.5%
Compound 4: middle estimate off by 21.5 percentage points, on the high side, and the stated range ends above it.
By their numbers in this assay, from the lowest: compound 4; then compounds 3 and 2 (each within the scatter of the next); then compound 1.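

In this assay, the earlier exchange between substituted phenyl groups stayed within the scatter, but the aryl group at this position can move the read-out further: with 2-fluorophenyl in place of 4-bromophenyl there is a number 17.1 percentage points lower from compound 3 to compound 4 (beyond the scatter), and with 2-fluorophenyl in place of 4-acetylphenyl there is a number 18.3 percentage points lower from compound 2 to compound 4 (beyond the scatter). Set against the unsubstituted phenyl, the fluoro compound also shows a number 30 percentage points lower from compound 1 to compound 4 (beyond the scatter). So substituted phenyl groups at this position are not interchangeable in this read-out, and a single fluoro group can separate one from the others.

No available evidence explains this drop. The compounds shown change both the halogen and its place on the phenyl ring at once, leaving open which matters, and how a phenyl bearing an amine or a carboxylic acid would read.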